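From phenethyl to 4-chlorophenyl on a sulfur

A few compounds are considered here, and "the series" means these few. Any claim that something is new, unique, unknown or untested is made for them only; others in the source may bear on it.

Measured so far in a functional assay on A-375 cells (Homo sapiens) for inhibition, read by CCK-8 assay, with a stated time of 72 h, tested at 2 uM; a higher number here means more inhibition of growth at the concentration tested, a lower number less inhibition of growth:
- compound 1 `CCc1ccc(SCc2ccc(C(=O)Nc3ccccc3N)cc2)cc1` gives 19.6%
- compound 2 `Nc1ccccc1NC(=O)c1ccc(CSc2cccc(F)c2)cc1` gives 37.7%
- compound 3 `Nc1ccccc1NC(=O)c1ccc(CSCCc2ccccc2)cc1` gives 21.8%

Compound 3 at 21.8% cannot be told apart from compound 1 and lies clearly under compound 2. The step of a number 2.2 percentage points higher from compound 1 to compound 3 (within the scatter) is small, while the step of a number 15.9 percentage points lower from compound 2 to compound 3 (beyond the scatter) is modest. Compound 4 `Nc1ccccc1NC(=O)c1ccc(CSc2ccc(Cl)cc2)cc1` changes one group, 4-chlorophenyl in place of phenethyl on a sulfur with 4-chlorophenyl in place of phenethyl on a sulfur. Both steps bear on this change when read in reverse. Leaving phenethyl for the group of compound 1 shows nothing beyond the scatter, and leaving it for the group of compound 2 shows a modest rise. Within the data shown here, no measured compound carries 4-chlorophenyl, so only a small rise or none is expected in this assay here. The expected step is a number 6.2 percentage points higher from compound 3 to compound 4 (within the scatter) as an estimate. Compound 4 is expected at 28% with an estimated range from 15% to 43% overall.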

Compound 4, percent growth inhibition at one concentration: 25.3%
Beside the measured number, compound 4's estimate is 2.7 percentage points above it, and the stated range covers the measured number.
By their numbers in this assay, from the lowest: compounds 1, 3 and 4 (each within the scatter of the next); then compound 2.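

In this assay, 4-chlorophenyl on the sulfur cannot be told apart from phenethyl (a number 3.5 percentage points higher from compound 3 to compound 4 (within the scatter)) or from 4-ethylphenyl, where chloro stands in place of ethyl (a number 5.7 percentage points higher from compound 1 to compound 4 (within the scatter)). Only 3-fluorophenyl stands clear of it (a number 12.4 percentage points lower from compound 2 to compound 4 (beyond the scatter)), so a halogen on the ring does not by itself place a compound with compound 2. Nothing at hand explains this difference.

Still open, as far as these compounds go, is whether 3-chlorophenyl on the sulfur would read like compound 2 or like compound 4. Also open, from the compounds shown here alone, is how a phenyl ring carrying an amine or a carboxylic acid would read here.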